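The source may hold more compounds than are shown below. What is called first, only, known or untested is meant among the compounds shown, and "the series" means these compounds.

Working notes on the series, read in a functional assay on LoVo cells (Homo sapiens) for inhibition, read by MTT assay, with a stated time of 48 h (on this read-out lower numbers stand for stronger inhibition and higher numbers for weaker inhibition), throughout. With a shared core and one varied group on an aromatic carbon, compound 1 (`COc1ccc(N(C)c2nc(C)nc3ccccc23)cc1C(=O)OCCC[Se]C#N`) gives 854 nM and compound 2 (`COc1ccc(N(C)c2nc(C)nc3ccccc23)cc1[Se]C`) gives 3 nM in this read-out. Compound 3 (`COc1ccc(N(C)c2nc(C)nc3ccccc23)cc1OCC[Se]C#N`) gives 19 nM and so stands second highest of the three numbers. The next compound, not yet measured, is compound 4 (`COc1ccc(N(C)c2nc(C)nc3ccccc23)cc1OCCCC[Se]C#N`). Its change from compound 3 is a group of 5 heavy atoms (3 carbon, 1 nitrogen, 1 selenium; no ring) in place of a group of 3 heavy atoms (1 carbon, 1 nitrogen, 1 selenium; no ring), on a saturated chain carbon, two bonds along the chain from an oxygen on an aromatic ring on a saturated chain carbon, two bonds along the chain from an oxygen on an aromatic ring.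

For the measured compounds named here, no measured step isolates this change, as each one replaces the whole group on the aromatic carbon. The closest evidence is a 6.3-fold higher number from compound 2 to compound 3 (0.80 log units; beyond the scatter) (modest), along with a 45-fold lower number from compound 1 to compound 3 (1.65 log units; beyond the scatter) and a 280-fold lower number from compound 1 to compound 2 (2.45 log units; beyond the scatter) (both large). Across these three compounds the larger group carries the higher number, and none goes against this, but compound 1 also differs by its carbonyl, so the large steps are only a loose guide.

For compound 4 a small rise is expected in this assay, estimated as a 1.6-fold higher number from compound 3 to compound 4 (0.20 log units; within the scatter) and possibly no more than scatter. For compound 4 the estimated value is 30 nM with an expected range from 9 nM to 100 nM on this read-out.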

Compound 4, half-maximal inhibitory concentration: 882 nM
Beside the measured number, compound 4's estimate is 29-fold (1.47 log units) below it, and the stated range ends below it.
By their numbers in this assay, from the lowest: compound 2; then compound 3; then compounds 1 and 4 (each within the scatter of the next).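

In this assay the saturated chain carbon, two bonds along the chain from an oxygen on an aromatic ring, proves sensitive: a group of 5 heavy atoms in place of a group of 3 heavy atoms gives a 46-fold higher number from compound 3 to compound 4 (1.67 log units; beyond the scatter) with the nitrile and the selenium present in both groups, so this step isolates chain length, which the earlier whole-group replacements could not do. The longer group also gives a 290-fold higher number from compound 2 to compound 4 (2.47 log units; beyond the scatter) on the aromatic carbon, while a 1.0-fold higher number from compound 1 to compound 4 (0.01 log units; within the scatter) places it level with the group bearing the carbonyl, which shows that the carbonyl is not required for a number at that level. Nothing available accounts for the size of the chain step.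

The compounds shown give only two lengths of the oxygen-linked chain, so they leave open whether the number climbs gradually or jumps at a particular length, and how a still longer chain would read. They also leave open whether the rise depends on the selenium and nitrile end of the chain, which sulfur in place of selenium or a terminal amine or carboxylic acid would test.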